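Fluoro for Methoxy in a Series at the Assay Limit

The source may hold more compounds than are shown below. What is called first, only, known or untested is meant among the compounds shown, and "the series" means these compounds.

Compound 1 `NS(=O)(=O)NCC1CCN(c2cc(-c3ccccc3)ncn2)CC1` reaches only the limit > 100000 nM in a functional assay on HT-29 cells (Homo sapiens) for antiproliferative activity, read by sulforhodamine B assay, with a stated time of 48 h; a lower number here means a stronger inhibitor of growth, a higher number a weaker inhibitor of growth.
Compound 2 `COc1ccccc1-c1cc(N2CCC(CNS(N)(=O)=O)CC2)ncn1` likewise sits at the limit > 100000 nM in this assay.

Compound 2 therefore stands at the limit of this assay, and it shares that position with every value shown (the limit of > 100000 nM in this assay, at which 2 of the 2 values shown sit). For the measured compounds named here, the single measured step, a step that the two limits leave unreadable from compound 1 to compound 2, cannot be read in size or direction from two limits. Compound 3 `NS(=O)(=O)NCC1CCN(c2cc(-c3ccccc3F)ncn2)CC1` differs from compound 2 by fluoro in place of methoxy on an aromatic carbon. Going by the values given here, no measured step bears directly on a change of this kind, and the one step available gives no readable size, so neither a gain nor a loss beyond the scatter can be predicted. The step of a number no higher from compound 2 to compound 3 (the limit leaves the size open) is expected to leave compound 3 where compound 2 sits, at or near the limit. Compound 3 is accordingly estimated at 100000 nM, with a range from 20000 nM to 300000 nM.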

Compound 3, concentration for 50% growth inhibition: 80400 nM
Estimate against measurement, compound 3: 1.2-fold (0.09 log units) above, within the range that was stated.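

In this assay, for the compounds shown here, compound 3 gives 80400 nM, the only reading among the three compounds that is a number and not a limit of the assay. The steps it opens are an at least 1.2-fold lower number from compound 2 to compound 3 (0.09 log units; that floor lies within the scatter) and an at least 1.2-fold lower number from compound 1 to compound 3 (0.09 log units; that floor lies within the scatter), so neither fluoro in place of methoxy nor fluoro in place of hydrogen, ortho to a large group, is shown to change growth inhibition beyond the scatter. The series as a whole still sits almost entirely at the edge of what the assay can read: the limit of > 100000 nM in this assay, at which 2 of the 3 values shown sit.

The compounds shown leave open whether a chloro, a nitrile or an amine at this place would give a number clearly beyond the scatter. They also leave open how far compound 1 and compound 2 lie past their limit, and with it the true size of both steps.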